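The source may hold more compounds than are shown below. What is called first, only, known or untested is meant among the compounds shown, and "the series" means these compounds.

Of the compounds shown here, two have so far been measured in a functional assay on A549 cells (Homo sapiens) for antiproliferative activity, read by MTT assay, with a stated time of 48 h, in the presence of a further agent that is not named here; on this read-out higher numbers stand for weaker inhibition of growth and lower numbers for stronger inhibition of growth. Compound 1 `COc1ccc(-c2nn(-c3ccccc3)cc2C(=O)NOCc2ccccc2)cc1` gives 1940 nM in this assay, and compound 2 `COc1ccc(-c2nn(-c3ccccc3)cc2C(=O)NOCc2ccccc2Cl)cc1` gives 2450 nM. Within the data shown here, the only step between them, a 1.3-fold higher number from compound 1 to compound 2 (0.10 log units; within the scatter), leaves the two within the usual scatter of each other. Compound 2 therefore carries the higher of the two numbers on record, but not by a margin that counts as a real difference.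

Compound 3 `O=C(NOCc1ccccc1Cl)c1cn(-c2ccccc2)nc1-c1ccc(F)cc1` is the next compound and is still unmeasured. It differs from compound 2 in one place: fluoro in place of methoxy on an aromatic carbon. Among the measured compounds shown here, no measured step bears directly on this change, since the one known step altered a different ring of the shared core. With nothing pointing either way, the step of a 1.2-fold higher number from compound 2 to compound 3 (0.09 log units; within the scatter) is expected to stay within the scatter. Compound 3 is accordingly estimated at 3000 nM in this assay, with a likely range from 1200 nM to 7500 nM.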

Compound 3, concentration for 50% growth inhibition: 8330 nM
For compound 3 the middle estimate is 2.8-fold (0.44 log units) below the measured one; the measured number lies above the stated range.
By their numbers in this assay, from the lowest: compounds 1 and 2 (each within the scatter of the next); then compound 3.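

Among these compounds, changing 4-methoxyphenyl to 4-fluorophenyl gives the first step on record to exceed the scatter in this assay: a 3.4-fold higher number from compound 2 to compound 3 (0.53 log units; beyond the scatter). Among the compounds shown here, the group at this position, para to a large group, therefore matters to growth inhibition, with methoxy giving the lower number and so the stronger inhibition of the pair, unlike the only earlier step, a 1.3-fold higher number from compound 1 to compound 2 (0.10 log units; within the scatter). No measurement available here explains why the two groups differ.

For the compounds shown here, with only two groups seen at this position, it remains open whether a hydroxyl, an ethoxy or a dimethylamino group would give a number closer to that of compound 2 or compound 3. From the compounds shown here alone, it is also open whether the same change from methoxy to fluoro would produce a similar step on compound 1, which has no chloro group.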